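This account rests on a few compounds, and the source may have more. Where it says the series, first, only, none or still open, it means among the compounds named here.

Among the measured compounds shown here, in a functional assay on MCF7 cells (Homo sapiens) for cytotoxicity, with a stated time of 72 h (a higher number here means a weaker inhibitor, a lower number a stronger inhibitor), compound 2 `Cc1cccc(-c2nn3c(c2-c2ccnc(Nc4ccc(S(N)(=O)=O)cc4)c2)C(C)C(C)(C)C3)n1` gives 22000 nM, the only true number so far. Compound 3 `Cc1cccc(-c2nn3c(c2-c2ccncc2)C(C)C(C)(C)C3)n1` has yet to be measured and differs from compound 2 by hydrogen in place of (4-sulfamoylphenyl)amino on an aromatic carbon, with hydrogen in place of (4-sulfamoylphenyl)amino on an aromatic carbon. A clear upward step in this assay, towards weaker inhibition, is expected, since compound 1 `Cc1cccc(-c2nn3c(c2-c2ccncc2)CC(C)(C)C3)n1`, which also lacks that group, sits at > 100000 nM, a limit of the assay and not a number. The expected change is a 4.5-fold higher number from compound 2 to compound 3 (0.66 log units; beyond the scatter). For compound 3 the estimated value is 100000 nM, with an expected range of 45000 nM to 220000 nM.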

Compound 3, half-maximal inhibitory concentration: > 100000 nM
Compound 3 ended at the assay's limit; the forecaster's own chance of this, stated with the estimate: 75%; the middle value sits exactly at the limit.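

In this assay, hydrogen in place of (4-sulfamoylphenyl)amino, on an aromatic carbon next to the ring nitrogen, gives an at least 4.5-fold higher number from compound 2 to compound 3 (0.65 log units; beyond the scatter). Among the compounds shown here, this is the first comparison with the methyl on the saturated ring carbon present on both sides, and it ties the measurable value of compound 2 to this group. On these data alone, the step from compound 1 to compound 3 cannot be read, and the upper size of the new step stays unknown, as compound 3 gives a limit and not a number: the limit of > 100000 nM in this assay, at which 2 of the 3 values shown sit. Open, as far as these compounds go, is whether a plain amine or an unsubstituted phenylamino group on that carbon would keep the value of compound 2.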